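Methoxy for nitro on a benzimidazole-type core: cytotoxicity outlook

The source may hold more compounds than are shown below. What is called first, only, known or untested is meant among the compounds shown, and "the series" means these compounds.

Among the measured compounds shown here, compound 2 `O=[N+]([O-])c1ccc(-c2nc3cc(Cl)c(Cl)cc3[nH]2)cc1` is one of two compounds measured in an ADME assay on MT4 cells (Homo sapiens) for cytotoxicity, read by MTT assay, with a stated time of 96 h; on this read-out lower numbers stand for higher toxicity in this test and higher numbers for lower toxicity in this test. In this assay compound 2 gives 17000 nM, the highest of the two numbers, so it is the less toxic of the pair. Its nearest neighbour is compound 1 `COc1ccc(-c2nc3cc(Cl)c(Cl)cc3[nH]2)c(N)c1`, which carries methoxy and an amino group on the pendant ring; in this assay compound 1 gives 3000 nM, a lower number, and the gap between the two lies beyond the usual scatter of repeated measurements.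

Compound 3 `COc1ccc(-c2nc3cc(Cl)c(Cl)cc3[nH]2)cc1` has not yet been measured. It differs from compound 2 in one place: methoxy in place of nitro on an aromatic carbon. For the measured compounds named here, no step between measured compounds matches this change, so only the two values shown can guide an expectation.

The author expects compound 3 to move towards a lower number than compound 2, a step of modest size, estimated as a 2.8-fold lower number from compound 2 to compound 3 (0.45 log units; beyond the scatter), since compound 1, which also bears methoxy, gives 3000 nM. For compound 3 in this assay the estimated value is 6000 nM, with a range from 2000 nM to 20000 nM.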

Compound 3, half-maximal cytotoxic concentration: 1000 nM
The estimate for compound 3 lay 6.0-fold (0.78 log units) above the measured number, outside the stated range (below it).
By their numbers in this assay, from the lowest: compound 3; then compound 1; then compound 2.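

In this assay, among the compounds shown here, methoxy in place of nitro on an aromatic carbon, para to a large group, is a large change (a 17-fold lower number from compound 2 to compound 3 (1.23 log units; beyond the scatter)), and this is the first reading of that single swap, since compound 1 and compound 2 differ in more than one place. The amino group can now be read on its own as well: with methoxy held in place, hydrogen in place of amino on an aromatic carbon gives a modest step (a 3.0-fold lower number from compound 1 to compound 3 (0.48 log units; beyond the scatter)), which leaves compound 3 with the lowest number of the three and so the highest toxicity in this test, with both of its steps beyond the usual scatter. Nothing available here accounts for the size or direction of either step.

The compounds shown leave open where other groups at this place, such as ethoxy, trifluoromethyl or a carboxylic acid, would fall relative to nitro and methoxy. They also leave open whether the step from nitro to methoxy would keep its size with an amino group on the same ring, and whether the order of the three compounds would hold in another cell line.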